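Furanyl Branch Replaces Benzyl on the Acylguanidine Urea

A few compounds are considered here, and "the series" means these few. Any claim that something is new, unique, unknown or untested is made for them only; others in the source may bear on it.

Compound 1, `Cc1nc(N)sc1CCCN/C(N)=N/C(=O)NC(c1ccccc1)c1ccccc1`, gives 331 nM in a functional assay on HEK293T cells for agonist activity at histamine H2 receptor (Homo sapiens), read by beta-arrestin recruitment; on this read-out higher numbers stand for an effect only at larger amounts of compound and lower numbers for an effect already at smaller amounts.
Compound 2, `Cc1nc(N)sc1CCCN/C(N)=N/C(=O)NCC(C)C1CCCCC1`, gives 224 nM in this assay.
Compound 3, `Cc1nc(N)sc1CCCN/C(N)=N/C(=O)NCc1ccccc1`, gives 100 nM in this assay.

Among the three measured compounds, compound 3 carries the lowest number, and both of its neighbours lie beyond the scatter: a 3.3-fold lower number from compound 1 to compound 3 (0.52 log units; beyond the scatter), and a 2.2-fold lower number from compound 2 to compound 3 (0.35 log units; beyond the scatter). Both steps show the same thing, that the plain benzyl on the amide-type nitrogen does better than either a second phenyl on the chain carbon or the branched cyclohexyl chain.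

The next compound, compound 4, `Cc1nc(N)sc1CCCN/C(N)=N/C(=O)NC(C)c1ccco1`, brings (1-(furan-2-yl)ethyl in place of benzyl on an amide-type nitrogen), the amide-type nitrogen keeping its carbonyl carbon as the other neighbour. The change both swaps the six-membered carbon ring for the five-membered ring with one oxygen and adds a methyl branch to the chain carbon. The step from compound 1 to compound 3 bears on the branching: a substituent on that carbon raised the number, and the step from compound 2 to compound 3 points the same way for a branched chain. The effect of the ring swap itself is not shown by any measured pair.

A modest rise in this assay is therefore expected for compound 4, namely a 2.0-fold higher number from compound 3 to compound 4 (0.30 log units; within the scatter), giving an estimate of 200 nM within 80 nM to 500 nM.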

Compound 4, half-maximal effective concentration: 234 nM
The estimate for compound 4 lay 1.2-fold (0.07 log units) below the measured number; measured number inside the range.
By their numbers in this assay, from the lowest: compound 3; then compounds 2, 4 and 1 (each within the scatter of the next).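

Replacing benzyl on the amide-type nitrogen with 1-(furan-2-yl)ethyl gives, in this assay, a 2.3-fold higher number from compound 3 to compound 4 (0.37 log units; beyond the scatter) and this happens although the two groups have the same heavy-atom count, so the rise here does not come with any gain in heavy atoms, and the hydrogen-bond acceptor that enters with the ring oxygen does not bring the number down. With this result, all three groups shown on this nitrogen that differ from the benzyl of compound 3 give higher numbers, and none of the compounds shown goes against that, so benzyl holds up against a five-membered aromatic ring with a hetero atom as well as against the two carbon-only groups. No measurement given here accounts for this rise.

The change alters the ring and adds the methyl branch in one step, so its effect cannot be divided between them. A 1-phenylethyl group, which keeps the benzene ring with the branch, and an unbranched furan-2-ylmethyl group, which keeps the furan without it, would each isolate one of the two parts.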